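A Hydroxamic Acid Replaces the Ester of Compound 1

This account rests on a few compounds, and the source may have more. Where it says the series, first, only, none or still open, it means among the compounds named here.

Compound 1 `C=C(CC)C(=O)c1ccc(OCC(=O)Nc2ccc(C(=O)OC)cc2)c(Cl)c1Cl`: 4100 nM
Compound 2 `C=C(CC)C(=O)c1ccc(OCC(=O)Nc2ccc(C(=O)O)cn2)c(Cl)c1Cl`: 14900 nM
Compound 3 `C=C(CC)C(=O)c1ccc(OCC(=O)NCC2CCC(C(=O)O)CC2)c(Cl)c1Cl`: 8000 nM

Of the compounds shown here, three sharing one core have been measured in a functional assay on CLL cells (Homo sapiens) for cytotoxicity, read by MTT assay, with a stated time of 48 h; a lower number here means that less compound is needed, a higher number that more compound is needed for the effect. Compound 1 gives the lowest number of the three; compound 3 lies within the usual scatter of it, while compound 2 sits beyond the scatter. Compound 4 `C=C(CC)C(=O)c1ccc(OCC(=O)Nc2ccc(/C=C/C(=O)NO)cc2)c(Cl)c1Cl` has not yet been measured. It differs from compound 1 in one place: 2-(hydroxycarbamoyl)ethenyl in place of methoxycarbonyl on an aromatic carbon. Among the compounds with values here, no step between the measured compounds resembles this change, so the expectation rests on compound 1 alone. A moderate step toward a lower number is expected from compound 1 to compound 4, a 2.1-fold lower number from compound 1 to compound 4 (0.31 log units; beyond the scatter), though a result within the scatter would not be surprising. Compound 4 is estimated at 2000 nM, with an expected range from 700 nM to 6000 nM.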

Compound 4, half-maximal effective concentration: 2600 nM
The estimate for compound 4 lay 1.3-fold (0.11 log units) below the measured number; the range from low to high includes it.
By their numbers in this assay, from the lowest: compounds 4, 1, 3 and 2 (each within the scatter of the next, the first and the last beyond it).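

At the aromatic carbon para to a large group, 2-(hydroxycarbamoyl)ethenyl replaces methoxycarbonyl in this assay with a step that stays within the scatter (a 1.6-fold lower number from compound 1 to compound 4 (0.20 log units; within the scatter)). This position therefore holds the group with more heavy atoms, and the exchange gives no change that can be told from scatter. Nothing at hand bears on the reason for this result. Open, as far as these compounds go, is whether a carboxylic acid at the end of the ethenyl chain, or a saturated ethyl chain carrying the hydroxycarbamoyl end, would give a number beyond the scatter of these two.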